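Methyl on the ring: from compound 1 to compound 3

This account rests on a few compounds, and the source may have more. Where it says the series, first, only, none or still open, it means among the compounds named here.

- compound 1 `CC(=O)N(C)C(C)C#CCn1ccnc1`: 3 mg/kg
- compound 2 `CC(=O)N(C)C(C)C#CCn1cncc1C`: > 100 mg/kg (a limit of the assay)
- compound 3 `CC(=O)N(C)C(C)C#CCn1ccnc1C`: not yet measured

Among the measured compounds shown here, in a functional assay on the whole organism for agonist activity, with Mus musculus as the target (on this read-out lower numbers stand for an effect already at smaller amounts and higher numbers for an effect only at larger amounts of compound), compound 1 gives 3 mg/kg, the only actual number so far. Compound 2 is reported only as a limit, > 100 mg/kg.

Compound 3 differs from compound 1 by methyl in place of hydrogen on an aromatic carbon. This is methyl in place of hydrogen on an aromatic carbon, between two ring nitrogen atoms, next to the ring atom that bears a large group.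

For the measured compounds named here, one measured step bears on this change. It is an at least 33-fold higher number from compound 1 to compound 2 (1.52 log units; beyond the scatter), a large step for the same kind of replacement made on a different ring carbon. This single precedent points towards a higher number for compound 3 in this assay, but its size may not carry over to the new place, and the true size of the measured step is itself unknown.

The expected step is a 10-fold higher number from compound 1 to compound 3 (1.00 log units; beyond the scatter). Compound 3 is estimated at 30 mg/kg, with an expected range of 6 mg/kg to 150 mg/kg.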

Compound 3, dose for half-maximal effect: > 100 mg/kg
Compound 3: a limit, no number; the forecaster's own chance of this, stated with the estimate: 45%; middle value at least 3.3-fold (0.52 log units) away from the limit.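

At the ring carbon between two ring nitrogen atoms, next to the ring atom that bears a large group, methyl in place of hydrogen gives an at least 33-fold higher number from compound 1 to compound 3 (1.52 log units; beyond the scatter) in this assay, so the large step seen with compound 2 is not confined to one ring carbon. Among the compounds shown, only compound 1, with hydrogen on both of these ring carbons, gives an actual number, 3 mg/kg. Compound 3 sits at a limit of the assay, so the true size of its step is unknown and the two methyl places cannot be ranked against each other: the limit of > 100 mg/kg in this assay, at which 2 of the 3 values shown sit.

Still open, on these data alone, is whether methyl is a special case at these ring carbons, or whether a fluorine, a chlorine or an amine in the same place would also give a value at the limit or would bring back an actual number. The compounds shown also leave open whether the same pattern would hold in a read-out other than one on the whole organism.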